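A Decyl Tail Replaces the Sulfonamide on the Triazole Arm

The source may hold more compounds than are shown below. What is called first, only, known or untested is meant among the compounds shown, and "the series" means these compounds.

Compound 1 `O=C1O[C@H]([C@@H](O)Cn2cc(CNS(=O)(=O)c3ccc(F)cc3)nn2)C(OCc2ccccc2)=C1OCc1ccccc1` is the reference point of this account. In a functional assay on A549 cells (Homo sapiens) for antiproliferative activity, read by MTT assay, with a stated time of 72 h (a lower number here means a stronger inhibitor, a higher number a weaker inhibitor), compound 1 gives 22500 nM, the only number among the three results shown. Compound 2 `O=C1O/C(=C\Cn2cc(-c3ccc(Br)cc3)nn2)C(OCc2ccccc2)=C1OCc1ccccc1` reaches only a limit of the assay in this assay, at > 100000 nM. Compound 3 `O=C1O/C(=C\Cn2cc(-c3cc(C(F)(F)F)cc(C(F)(F)F)c3)nn2)C(OCc2ccccc2)=C1OCc1ccccc1` likewise gives only a limit in this assay, > 100000 nM. Within the data shown here, these two limits make up (the limit of > 100000 nM in this assay, at which 2 of the 3 values shown sit), so compound 1 stands alone as the one measured number, with the other two compounds sitting at the limit. Compound 4 `CCCCCCCCCCc1cn(C[C@H](O)[C@H]2OC(=O)C(OCc3ccccc3)=C2OCc2ccccc2)nn1` differs from compound 1 in one place: nonyl in place of ((4-fluorophenyl)sulfonyl)amino on a saturated chain carbon bound to an aromatic carbon. Among the measured compounds shown here, no step between measured compounds is available, so the size of this change rests on expectation alone. The nonyl chain entering in place of the ((4-fluorophenyl)sulfonyl)amino group is expected to move the value toward stronger inhibition by a step beyond the usual scatter. Compound 4 is thus expected to give about 8000 nM in this assay, within a range from 2000 nM to 40000 nM, which corresponds to the expected step of a 2.8-fold lower number from compound 1 to compound 4 (0.45 log units; beyond the scatter).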

Compound 4, half-maximal inhibitory concentration: 6750 nM
The estimate for compound 4 lay 1.2-fold (0.07 log units) above the measured number; the measured number falls inside the stated range.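

Exchanging the ((4-fluorophenyl)sulfonyl)amino group for nonyl on a saturated chain carbon bound to an aromatic carbon gives, in this assay, a 3.3-fold lower number from compound 1 to compound 4 (0.52 log units; beyond the scatter). Among these compounds, this is the first measured change at this position, and it shows that the sulfonamide and its aromatic ring are not needed for compound 4 to give a measured number, since a plain chain with no ring goes with the stronger inhibition. Nothing measured here accounts for the step.

Steps linking compounds 2 and 3 to the others cannot be read. From the compounds shown here alone, whether a longer chain, a shorter chain or an amine at the same place would move the number further stays open, as does whether the step comes from gaining the nonyl chain or from losing the sulfonamide.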